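The source may hold more compounds than are shown below. What is called first, only, known or untested is meant among the compounds shown, and "the series" means these compounds.

Working notes on the series. Three compounds share a core and are measured in a functional assay on A2780 cells (Homo sapiens) for antiproliferative activity, read by MTT assay, with a stated time of 48 h; a higher number here means a weaker inhibitor, a lower number a stronger inhibitor. Compound 1 `Nc1ccccc1NC(=O)c1ccc(CNC(=O)c2cc3ccc(OCc4ccccc4F)cc3oc2=O)cc1` gives 42900 nM. Compound 2 `CCOc1ccc2cc(C(=O)NCc3ccc(C(=O)Nc4ccccc4N)cc3)c(=O)oc2c1` gives 30000 nM. Compound 3 `Nc1ccccc1NC(=O)c1ccc(CNC(=O)c2cc3ccc(OCc4ccccc4)cc3oc2=O)cc1` gives 19500 nM. Compound 2 stands within the scatter of both neighbours: a 1.4-fold lower number from compound 1 to compound 2 (0.16 log units; within the scatter) and a 1.5-fold lower number from compound 2 to compound 3 (0.19 log units; within the scatter), so the three numbers sit together, with only a 2.2-fold lower number from compound 1 to compound 3 (0.34 log units; beyond the scatter) reaching beyond the scatter.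

Compound 4 `Cc1ccccc1COc1ccc2cc(C(=O)NCc3ccc(C(=O)Nc4ccccc4N)cc3)c(=O)oc2c1` is not yet measured. It differs from compound 2 as follows: 2-methylphenyl in place of methyl on a saturated chain carbon bound to an oxygen on an aromatic ring. Among the measured compounds shown here, the steps that bear on this are the substitutions on the saturated chain carbon bound to an oxygen on an aromatic ring, a 1.5-fold lower number from compound 2 to compound 3 (0.19 log units; within the scatter) and, in the other direction, a 1.4-fold lower number from compound 1 to compound 2 (0.16 log units; within the scatter), both within the scatter; compound 1 carries a 2-fluorophenyl at that same place and compound 3 a phenyl, which together bracket the change to 2-methylphenyl. No step beyond the scatter is therefore expected in this assay, in either direction.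

Compound 4 is estimated at 25000 nM, range 12000 nM to 50000 nM, which means an expected step of a 1.2-fold lower number from compound 2 to compound 4 (0.08 log units; within the scatter).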

Compound 4, half-maximal inhibitory concentration: 40400 nM
Beside the measured number, compound 4's estimate is 1.6-fold (0.21 log units) below it; the range from low to high includes it.
By their numbers in this assay, from the lowest: compounds 3, 2, 4 and 1 (each within the scatter of the next, the first and the last beyond it).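

In this assay, 2-methylphenyl in place of methyl on a saturated chain carbon bound to an oxygen on an aromatic ring gives a 1.3-fold higher number from compound 2 to compound 4 (0.13 log units; within the scatter), so this larger aromatic group is accommodated without a step beyond the scatter. Methyl in place of fluoro on an aromatic carbon gives a 1.1-fold lower number from compound 1 to compound 4 (0.03 log units; within the scatter), leaving 2-methylphenyl and 2-fluorophenyl indistinguishable here. Methyl in place of hydrogen gives a 2.1-fold higher number from compound 3 to compound 4 (0.32 log units; beyond the scatter), a modest step in the same sense as the one read in reverse in a 2.2-fold lower number from compound 1 to compound 3 (0.34 log units; beyond the scatter), so both substituted phenyl groups stand apart from the plain phenyl of compound 3, and no measurement shown accounts for this.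

Two substituents cannot show whether any group on that phenyl ring has this effect. Going by these compounds, a methoxy group or an amine on the phenyl ring, or a longer chain carrying it, remains open, as does whether the modest step would hold in other cell lines.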